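This account rests on a few compounds, and the source may have more. Where it says the series, first, only, none or still open, it means among the compounds named here.

The three measured compounds, all in a functional assay on NUGC-3 cells (Homo sapiens) for inhibition, read by sulforhodamine B assay, with a stated time of 48 h; a higher number here means a weaker inhibitor of growth, a lower number a stronger inhibitor of growth:
compound 1, `O=C(Nc1cccc(C(F)(F)F)c1)C1NCCc2ccccc21`, > 10000 nM;
compound 2, `O=C(Nc1ccc(O)cc1)c1nccc2ccccc12`, > 10000 nM;
compound 3, `O=C(Nc1cccc(C(F)(F)F)c1)c1nccc2ccccc12`, > 10000 nM.

Each of these values is a limit of the measurement rather than a number. Compound 2 thus stands at that limit, where the others also sit: the limit of > 10000 nM in this assay, at which 3 of the 3 values shown sit. For the measured compounds named here, no pair of measured compounds differs in a single place, so no measured step exists. The untested compound 4, `O=C(Nc1ccc(Cl)cc1)c1nccc2ccccc12`, arises from compound 2 by one change, (chloro in place of hydroxy on an aromatic carbon). Going by the values given here, with no measured step to lean on and every value a limit, the step that the limit leaves unreadable from compound 2 to compound 4 is expected to stay within the usual scatter, with no clear direction. Compound 4 is accordingly expected to sit near 15000 nM, within a range of 4000 nM to 60000 nM, most likely once more as a limit.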

Compound 4, concentration for 50% growth inhibition: > 10000 nM
Compound 4 gave a limit, no number; the forecaster's own chance of this, stated with the estimate: 70%; the middle value lies beyond the limit too.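

Compound 2 and compound 4 each give only a limit, not a number, so the size of the step between them cannot be read: the limit of > 10000 nM in this assay, at which 4 of the 4 values shown sit.

Which change to these compounds, if any, would bring growth inhibition into a measurable range stays open.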